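The source may hold more compounds than are shown below. What is called first, only, known or untested is meant among the compounds shown, and "the series" means these compounds.

Among the measured compounds shown here, compound 2 `COc1nc(C)c(Nc2nc(Cl)cn([C@H](COC(=O)Nc3cc(Cl)cc(Cl)c3)C3CC3)c2=O)cc1C` is one of two compounds measured in an assay on frontal cortex for displacement of a labelled ligand from corticotropin-releasing factor receptor 1 (Rattus norvegicus), with a stated time of 2 h (a higher number here means a weaker inhibitor, a lower number a stronger inhibitor), where compound 2 gives 1.7 nM. For the measured compounds named here, compound 1 `COc1nc(C)c(Nc2nc(Cl)cn([C@H](COC(=O)Nc3ccc(Cl)cc3)C3CC3)c2=O)cc1C` gives 1.6 nM in this assay, and the only step so far, a 1.1-fold higher number from compound 1 to compound 2 (0.03 log units; within the scatter), changes the aryl group on the carbamate and makes no difference beyond the scatter.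

Compound 3 `CCCCNC(=O)OC[C@H](C1CC1)n1cc(Cl)nc(Nc2cc(C)c(OC)nc2C)c1=O` carries a different kind of change: butyl in place of 3,5-dichlorophenyl on an amide-type nitrogen. The aromatic ring that both measured compounds share is exchanged for a short open chain. Going by the values given here, no measured step bears on this, since the one step available only varies the chlorine pattern on that ring while keeping the ring itself. The data therefore give no direct guide, and a modest weakening is expected rather than none, as a 2.9-fold higher number from compound 2 to compound 3 (0.47 log units; beyond the scatter). Compound 3 is expected to give about 5 nM in this assay, within a range from 1 nM to 30 nM.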

Compound 3, half-maximal inhibitory concentration: 4.7 nM
Beside the measured number, compound 3's estimate is 1.1-fold (0.03 log units) above it; measured number inside the range.
By their numbers in this assay, from the lowest: compounds 1 and 2 (each within the scatter of the next); then compound 3.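

Exchanging the aromatic ring on the amide-type nitrogen for an open chain moves the number beyond the scatter in this assay, which the change in chlorine pattern did not do: butyl in place of 3,5-dichlorophenyl gives a 2.8-fold higher number from compound 2 to compound 3 (0.44 log units; beyond the scatter), and butyl in place of 4-chlorophenyl gives a 2.9-fold higher number from compound 1 to compound 3 (0.47 log units; beyond the scatter). Both steps are modest, so an aromatic ring at this position is not essential for binding, since compound 3 still gives 4.7 nM. Nothing shown here explains this weakening.

Because the ring and its chlorine atoms leave together, these compounds cannot show which loss matters; an unsubstituted phenyl group would help separate the two. From the compounds shown here alone, it also remains open how a cyclohexyl ring or a longer chain would compare with butyl here.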